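A few compounds are considered here, and "the series" means these few. Any claim that something is new, unique, unknown or untested is made for them only; others in the source may bear on it.

Measured so far:
compound 1, `CCOc1ccc(C(=O)/C=C/c2c(/C=C/c3ccc(OC)cc3)cc(OC)cc2OC)cc1`, 6.4 ug/mL
compound 2, `CCCCCCOc1ccc(C(=O)/C=C/c2c(/C=C/c3ccc(OC)cc3)cc(OC)cc2OC)cc1`, 10.4 ug/mL
compound 3, `COc1ccc(/C=C/c2cc(OC)cc(OC)c2/C=C/C(=O)c2ccc(N)cc2)cc1`, 2.8 ug/mL

The three share one core and differ only in the group on the carbonyl-bearing ring. In a functional assay on B16-F10 cells (Mus musculus) for antiproliferative activity, read by MTT assay, with a stated time of 48 h (a higher number here means a weaker inhibitor, a lower number a stronger inhibitor), compound 3 stands at the lowest number of the three: compound 1 is nearest, with a 2.3-fold lower number from compound 1 to compound 3 (0.36 log units; beyond the scatter) running the other way, and compound 2 is furthest, as a 3.7-fold lower number from compound 2 to compound 3 (0.57 log units; beyond the scatter) shows. Between the two alkoxy compounds the step of a 1.6-fold higher number from compound 1 to compound 2 (0.21 log units; within the scatter) is within the scatter, so the two alkoxy groups are not separated by the data.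

Compound 4, `COc1ccc(/C=C/c2cc(OC)cc(OC)c2/C=C/C(=O)c2ccc(C)c(C)c2)cc1`, has not yet been measured. Its difference from compound 3 is 3,4-dimethylphenyl in place of 4-aminophenyl on a carbonyl carbon. For the measured compounds named here, the steps that bear on this change are a 2.3-fold lower number from compound 1 to compound 3 (0.36 log units; beyond the scatter) and a 3.7-fold lower number from compound 2 to compound 3 (0.57 log units; beyond the scatter), in both of which the amino compound gives the lower number; compound 4 moves away from the amino group, so a modest step back toward the numbers of compound 1 and compound 2 is expected, a 2.5-fold higher number from compound 3 to compound 4 (0.40 log units; beyond the scatter), rather than a further fall. Going by the values given here, no measured step tells how 3,4-dimethylphenyl compares with an alkoxy-bearing ring, so the expectation is loose. For compound 4 in this assay the estimate is 7 ug/mL, with a range from 3.5 ug/mL to 14 ug/mL.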

Compound 4, half-maximal inhibitory concentration: 1.4 ug/mL
Beside the measured number, compound 4's estimate is 5.0-fold (0.70 log units) above it, outside the stated range (below it).
By their numbers in this assay, from the lowest: compounds 4 and 3 (each within the scatter of the next); then compounds 1 and 2 (each within the scatter of the next).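

In this assay, placing 3,4-dimethylphenyl on the carbonyl carbon instead of 4-aminophenyl gives a 2.0-fold lower number from compound 3 to compound 4 (0.30 log units; within the scatter) and leaves the two groups unseparated, although the entering group has 0 hydrogen-bond donors and 0 hydrogen-bond acceptors where the leaving group has 1 of each. The amino group is therefore not needed for a number at this level in the series, and the earlier contrast between the amino compound and the alkoxy compounds no longer reads as specific to amino: the same position also gives a 4.6-fold lower number from compound 1 to compound 4 (0.66 log units; beyond the scatter) when 3,4-dimethylphenyl replaces 4-ethoxyphenyl, a modest step beyond the scatter. No measurement shown here accounts for this result.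

On these data alone, whether a single methyl group on the phenyl ring would match the 3,4-dimethylphenyl group, and whether a 4-hydroxyphenyl or 4-chlorophenyl group would fall with compound 3 and compound 4 or with compound 1, remains open. The reading also rests on one shared core and on one cell line, so how a dimethylamino group or a carboxylic acid would behave at this position, or how these groups would rank on a different core, stays undecided.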